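Trifluoromethyl for Nitrile on the Phenoxy Ring

The compounds below may be only part of what the source reports. "The series", "measured", "known", "first", "only" and "open" are said of these compounds alone.

Of the compounds shown here, three have been measured in a functional assay on MX1 cells (Homo sapiens) for antiproliferative activity, with a stated time of 72 h; a lower number here means that less compound is needed, a higher number that more compound is needed for the effect. Compound 1 `Cn1cc(-c2ccccc2Oc2ccccc2)cc(N)c1=O` reaches only a limit in this assay, > 5000 nM. Compound 2 `CCS(=O)(=O)Nc1ccc(Oc2ccccc2)c(-c2cn(C)c(=O)c3[nH]ccc23)c1` gives 14 nM. Compound 3 `CCS(=O)(=O)Nc1ccc(Oc2ccc(C#N)cc2)c(-c2cn(C)c(=O)c3[nH]ccc23)c1` gives 17 nM. Among the compounds with values here, the one measured step, a 1.2-fold higher number from compound 2 to compound 3 (0.08 log units; within the scatter), is within the scatter, so compound 3 stands level with compound 2 rather than apart from it. Compound 4 `CCS(=O)(=O)Nc1ccc(Oc2ccc(C(F)(F)F)cc2)c(-c2cn(C)c(=O)c3[nH]ccc23)c1` has not yet been measured; it differs from compound 3 by trifluoromethyl in place of cyano on an aromatic carbon. Within the data shown here, the only measured step that swaps a group on the phenoxy ring, a 1.2-fold higher number from compound 2 to compound 3 (0.08 log units; within the scatter), barely moved the number, so for compound 4 a step of a 1.2-fold higher number from compound 3 to compound 4 (0.07 log units; within the scatter) is expected, nothing beyond the scatter. Compound 4 is therefore estimated at 20 nM, with a range from 8 nM to 50 nM.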

Compound 4, half-maximal effective concentration: 30 nM
Compound 4: middle estimate off by 1.5-fold (0.18 log units), on the low side; the range from low to high includes it.
By their numbers in this assay, from the lowest: compounds 2, 3 and 4 (each within the scatter of the next, the first and the last beyond it). At a limit, above all of these: compound 1.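

In this assay the swap of nitrile for trifluoromethyl at this position gives a 1.8-fold higher number from compound 3 to compound 4 (0.25 log units; within the scatter) and so does not separate the two groups. Within the data shown here, measured against hydrogen, trifluoromethyl gives a 2.1-fold higher number from compound 2 to compound 4 (0.33 log units; beyond the scatter) as the first step at this position to pass beyond the scatter, though a modest one. Nothing shown explains this small shift. Still open, going by these compounds, is whether a different kind of group on this carbon, such as an amine or a carboxylic acid, would move the number further, or whether this position tolerates nearly anything.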